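The compounds below may be only part of what the source reports. "The series", "measured", "known", "first", "only" and "open" are said of these compounds alone.

Of the compounds shown here, two on the shared core have numbers so far in a physicochemical assay for lipophilicity, at pH 7.4; on this read-out lower numbers stand for lower lipophilicity and higher numbers for higher lipophilicity. Compound 1 `Cc1ccc(N(C2CCC2)S(=O)(=O)c2ccc3c(c2)C(O)CC(C2CCOCC2)O3)c(C)c1` reads 3.77, and compound 2 `CCc1ccc(N(CC(C)C)S(=O)(=O)c2ccc3c(c2)C(O)CC(C2CCN(S(C)(=O)=O)CC2)O3)cc1` reads 3.22. Compound 2 is the lower of the two, and its gap to compound 1 lies beyond the scatter. Going by the values given here, no two measured compounds differ in one place only, so the series offers no direct step to carry over.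

Compound 3 `CCc1ccc(N(CC(C)C)S(=O)(=O)c2ccc3c(c2)C(O)CC(C2CCOCC2)O3)cc1` is still unmeasured and departs from compound 2 in a single place: oxan-4-yl in place of 1-(methylsulfonyl)piperidin-4-yl on a saturated ring carbon. The exchange sits on a saturated ring carbon, next to the ring oxygen, and puts oxan-4-yl in place of 1-(methylsulfonyl)piperidin-4-yl. Among the compounds with values here, the only guide is compound 1, which already carries oxan-4-yl and gives 3.77, although it also differs from compound 3 elsewhere. On that single comparison, a rise is expected rather than a change within the scatter. The expected move is a number 0.48 log units higher from compound 2 to compound 3 (beyond the scatter). For compound 3 the estimated value in this assay is 3.7, with an expected range of 3.3 to 4.1.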

Compound 3, distribution coefficient: 4.12
Compound 3: the middle estimate sits 0.42 log units below what was measured, and the stated range ends below it.
By their numbers in this assay, from the lowest: compound 2; then compound 1; then compound 3.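

At the saturated ring carbon next to the ring oxygen, oxan-4-yl in place of 1-(methylsulfonyl)piperidin-4-yl gives a clean single-place read in this assay: a number 0.90 log units higher from compound 2 to compound 3 (beyond the scatter). The read-out therefore responds to the group at this position with the rest of compound 2 unchanged, which the gap between the two earlier compounds could not show, as they differ in more than one place. The exchange replaces 10 heavy atoms and 2 hydrogen-bond acceptors with 6 heavy atoms and 1 hydrogen-bond acceptor, but nothing at hand links either count, or any other feature of the two groups, to the size of this step.

On these data alone, the size of this step rests on one pair, so whether it carries over when other parts of the shared core change remains open. Also open, as far as these compounds go, is how a basic amine such as unsubstituted piperidin-4-yl, a carboxylic acid or an open alkyl chain would read at this saturated ring carbon, and therefore which part of 1-(methylsulfonyl)piperidin-4-yl accounts for the difference from oxan-4-yl.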